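The source may report more compounds than this note shows. Statements on the series, on what has been measured and on what is new or still open speak of the compounds shown alone.

Measured in a functional assay on U2OS cells (Homo sapiens) for antiproliferative activity, read by MTT assay, with a stated time of 72 h; on this read-out lower numbers stand for stronger inhibition and higher numbers for weaker inhibition:
compound 1 `O=C(CSc1nc2ccccc2[nH]1)Nc1ccc2nc(NC(=O)c3ccc(C(F)(F)F)cc3)sc2c1`: 7110 nM
compound 2 `O=C(CSc1cccc(O)c1)Nc1ccc2nc(NC(=O)c3ccc(F)cc3)sc2c1`: 5120 nM
compound 3 `O=C(CSc1ccc(Cl)cc1)Nc1ccc2nc(NC(=O)c3ccc4ccccc4c3)sc2c1`: 14500 nM

Compound 1 and compound 2 lie within the scatter of each other, so this pair cannot be ranked. Compound 3 gives a higher number than compound 1, beyond the scatter, which means weaker inhibition.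

Compound 4 `O=C(CSC1CCCCC1)Nc1ccc2nc(NC(=O)c3ccc(C(F)(F)F)cc3)sc2c1` keeps the core of compound 1 and changes one place: cyclohexyl in place of 1H-benzimidazol-2-yl on a sulfur. A non-aromatic ring of carbon only thus enters where aromatic rings stood.

For the measured compounds named here, no measured pair isolates this change, and no measured compound carries a non-aromatic ring on that sulfur. Compound 2 and compound 3 each differ from compound 1 in more than one place, so they offer only a general range. That range runs from compound 2 at 5120 nM to compound 3 at 14500 nM. As far as these compounds go, on this thin basis, no step beyond the scatter is expected in this assay, and the direction stays open.

The expected step is a 1.1-fold higher number from compound 1 to compound 4 (0.05 log units; within the scatter). For compound 4 the estimated value is 8000 nM, with an expected range from 3000 nM to 20000 nM.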

Compound 4, half-maximal inhibitory concentration: 12300 nM
Compound 4: the middle estimate sits 1.5-fold (0.19 log units) below what was measured; the measured number falls inside the stated range.
By their numbers in this assay, from the lowest: compounds 2, 1, 4 and 3 (each within the scatter of the next, the first and the last beyond it).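

In this assay, for the compounds shown here, the first pair that isolates this position gives a 1.7-fold higher number from compound 1 to compound 4 (0.24 log units; within the scatter), so the two compounds cannot be ranked. On the sulfur, then, cyclohexyl can stand in place of 1H-benzimidazol-2-yl without a step beyond the scatter, even though this swap gives up both aromatic rings, the ring nitrogens and the hydrogen-bond donor and acceptor counted for the leaving group. No measurement at hand explains this result or says what either group contributes in the cells.

A single pair cannot show whether this holds for other groups on the sulfur, such as an open butyl chain, an unsubstituted phenyl ring, a piperidine with its basic amine, or a carboxylic acid. It also leaves open whether the result carries over when the 4-(trifluoromethyl)benzoyl amide of compound 1 gives way to another acyl group, or whether a longer chain between the sulfur and the amide carbonyl would move the number beyond the scatter.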